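Swapping an Open Sulfonamide for a Ring in Compound 4

The source may hold more compounds than are shown below. What is called first, only, known or untested is meant among the compounds shown, and "the series" means these compounds.

Compound 1, `Cc1nc(N2CCC(NS(=O)(=O)N(C)C)CC2)nc2ccc(NC(=O)/C=C/c3ccc(OC(F)(F)F)cc3)cc12`, gives 31 nM in a functional assay on CHO-K1 cells for antagonist activity at melanin-concentrating hormone receptor 1 (Homo sapiens), read by inositol phosphate accumulation, with stated times of 10 min and 45 min; on this read-out lower numbers stand for stronger inhibition and higher numbers for weaker inhibition.
Compound 2, `Cc1nc(N2CCC(O)(C3CC3)CC2)nc2ccc(NC(=O)/C=C/c3ccc(C(F)(F)F)cc3)cc12`, gives 83 nM.
Compound 3, `CCCC1(O)CCN(c2nc(C)c3cc(NC(=O)/C=C/c4ccc(Cl)cc4)ccc3n2)CC1`, gives 91 nM.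

Among these three, compound 1 gives the lowest number in this assay. Compound 2 stands nearest to it and compound 3 furthest, and both gaps lie beyond the usual scatter of repeated measurements, so compound 1 is the strongest inhibitor of the measured set. Compound 4, `Cc1nc(N2CCC(N3CCCS3(=O)=O)CC2)nc2ccc(NC(=O)/C=C/c3ccc(OC(F)(F)F)cc3)cc12`, has not yet been measured. It differs from compound 1 in a single place: a group of 7 heavy atoms (3 carbon, 1 nitrogen, 2 oxygen, 1 sulfur; one five-membered non-aromatic ring with 2 hetero atoms) in place of a group of 7 heavy atoms (2 carbon, 2 nitrogen, 2 oxygen, 1 sulfur; no ring), on a saturated ring carbon. Everything else in the molecule stays the same. Among the measured compounds shown here, no pair of measured compounds differs in just one place, so there is no earlier step of this kind to lean on; the three measured compounds differ from each other in several places at once. Given that the group that enters and the group that leaves are counted at the same size, the step from compound 1 to compound 4 is expected to stay within the scatter, a 1.3-fold higher number from compound 1 to compound 4 (0.11 log units; within the scatter). Compound 4 is therefore estimated at 40 nM, with a range from 12 nM to 130 nM.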

Compound 4, half-maximal inhibitory concentration: 16 nM
Compound 4: the middle estimate sits 2.5-fold (0.40 log units) above what was measured; the range from low to high includes it.
By their numbers in this assay, from the lowest: compounds 4 and 1 (each within the scatter of the next); then compounds 2 and 3 (each within the scatter of the next).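

Among the compounds shown here, this is the first step in this assay that changes one place alone, and it reads a 1.9-fold lower number from compound 1 to compound 4 (0.29 log units; within the scatter). On this saturated ring carbon, then, the open (dimethylsulfamoyl)amino group can give way to a five-membered ring with no measurable change, even though the hydrogen-bond donor counted on the leaving group is absent from the entering one, so a number in this range does not depend on that donor. Nothing measured here explains why the two groups give such similar numbers.

As far as these compounds go, it remains open whether a six-membered ring holding the same sulfur and nitrogen, or a plain amine, would fit on this carbon equally well. It is also unknown whether the same swap would read alike without the trifluoromethoxy group that both compounds carry.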